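The source may report more compounds than this note shows. Statements on the series, on what has been measured and on what is new or still open speak of the compounds shown alone.

Among the compounds with values here, in an ADME assay on MT4 cells (Homo sapiens) for cytotoxicity (a higher number here means that more compound is tolerated, a lower number that less compound is tolerated), compound 2 `O=C(CSc1snnc1-c1ccc(Cl)cc1Cl)Nc1ccccc1F` gives 19500 nM, the only number recorded. Compound 1 `COc1ccc(-c2nnsc2SCC(=O)Nc2ccccc2Br)cc1` gives > 286000 nM in this assay, a limit of the assay rather than a number. Compound 3 `COc1ccc(-c2nnsc2SCC(=O)Nc2ccccc2F)cc1` differs from compound 2 by 4-methoxyphenyl in place of 2,4-dichlorophenyl on an aromatic carbon. No step between measured compounds is shown, so the size expected for this assay rests on the gap between the two values shown. Compound 3 is expected to be tolerated more, at 120000 nM between 35000 nM and 350000 nM, because compound 1 sits at the limit of > 286000 nM in this assay, at which 1 of the 2 values shown sits. The expected step is a 6.2-fold higher number from compound 2 to compound 3 (0.79 log units; beyond the scatter).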

Compound 3, half-maximal cytotoxic concentration: > 332000 nM
Compound 3 ended at the assay's limit; the forecaster's own chance of this, stated with the estimate: 40%; at least 2.7-fold (0.44 log units) between middle value and limit.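

In this assay, 4-methoxyphenyl in place of 2,4-dichlorophenyl on this aromatic carbon is now seen as a single change on the shared core, and it gives a large step: an at least 17-fold higher number from compound 2 to compound 3 (1.23 log units; beyond the scatter). Compound 3 gives > 332000 nM, a limit of the assay. The step from compound 1 to compound 3, fluoro in place of bromo on an aromatic carbon, cannot be read, since both values are limits.

On these data alone, it remains open whether the methoxy group or the loss of the two chloro groups carries this step. Plain phenyl, 4-chlorophenyl or 4-aminophenyl at this position could separate the two.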